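The source may report more compounds than this note shows. Statements on the series, on what has been measured and on what is new or still open speak of the compounds shown alone.

Compound 2 `Cc1ncccc1-c1nc2cn(-c3cccc(OC(C)C)c3)nc2c(=O)n1C[C@H]1CCCN(C[C@H]2CCCO2)C1` is the lower of the two numbers measured in an assay on HEK293 cells for displacement of a labelled ligand from growth hormone secretagogue receptor type 1 (Homo sapiens), with a stated time of 60 min (on this read-out lower numbers stand for stronger inhibition and higher numbers for weaker inhibition), where compound 2 gives 11 nM. Within the data shown here, its only neighbour, compound 1 `COc1ccc(-n2cc3nc(-c4cccnc4C)n(C[C@H]4CCCN(C[C@H]5CCCO5)C4)c(=O)c3n2)cc1`, gives 52 nM in this assay, and the step of a 4.7-fold lower number from compound 1 to compound 2 (0.67 log units; beyond the scatter) is the single measured comparison available. Compound 3 `Cc1ncccc1-c1nc2cn(-c3cccc(OC(F)F)c3)nc2c(=O)n1C[C@H]1CCCN(C[C@H]2CCCO2)C1` differs from compound 2 by difluoromethyl in place of isopropyl on an oxygen on an aromatic ring. Among the measured compounds shown here, no measured step bears directly on this exchange: the step from compound 1 to compound 2 swapped both the ring position and the alkyl group, so it offers no guide to a change of the alkyl group alone at the same oxygen. With nothing pointing either way, the expected step of a 1.4-fold higher number from compound 2 to compound 3 (0.13 log units; within the scatter) is one that stays within the scatter, in either direction. Compound 3 is therefore estimated at 15 nM in this assay, within a range of 5 nM to 45 nM.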

Compound 3, half-maximal inhibitory concentration: 27 nM
For compound 3 the middle estimate is 1.8-fold (0.26 log units) below the measured one; the measured number falls inside the stated range.
By their numbers in this assay, from the lowest: compound 2; then compounds 3 and 1 (each within the scatter of the next).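

Among these compounds, exchanging isopropyl for difluoromethyl on this oxygen gives a 2.5-fold higher number from compound 2 to compound 3 (0.39 log units; beyond the scatter) in this assay, the first reading of the group on the oxygen with the rest of the molecule held fixed. The 3-(difluoromethoxy)phenyl group of compound 3 also cannot be told apart from the 4-methoxyphenyl group of compound 1, as a 1.9-fold lower number from compound 1 to compound 3 (0.28 log units; within the scatter) shows, so among these three compounds the lowest number goes with the 3-isopropoxyphenyl group of compound 2 and not with every group tried at this ring position. Nothing in the data given here explains the difference between isopropyl and difluoromethyl.

Among the compounds shown here, only two groups can be compared directly on this oxygen, so the effect of a cyclopropyl ring, a trifluoromethyl group or a longer chain such as butyl remains open. Whether the same exchange would give a similar step on another core is also unknown.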